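Swapping the Group on the Carbonyl Carbon

The source may report more compounds than this note shows. Statements on the series, on what has been measured and on what is new or still open speak of the compounds shown alone.

Measured so far:
Compound 1 `Cc1nc(S(C)(=O)=O)ccc1Oc1ncnc(OC2CCN(C(=O)OC(C)(C)CF)CC2)c1F` gives 19.9 nM in a functional assay on isolated protein for inhibition of Glucose-dependent insulinotropic receptor (Homo sapiens), read by HTRF and cAMP accumulation; on this read-out higher numbers stand for an effect only at larger amounts of compound and lower numbers for an effect already at smaller amounts.
Compound 2 `Cc1nc(S(C)(=O)=O)ccc1Oc1ncnc(OC2CCN(C(=O)O[C@H](C)C(F)(F)F)CC2)c1F` gives 9.2 nM in this assay.

Among the compounds with values here, compound 1 holds the highest of the two numbers; the only measured step is a 2.2-fold lower number from compound 1 to compound 2 (0.34 log units; beyond the scatter). Compound 3 `CCC(F)(F)C(=O)N1CCC(Oc2ncnc(Oc3ccc(S(C)(=O)=O)nc3C)c2F)CC1` is not yet measured. It differs from compound 1 in a group of 5 heavy atoms (3 carbon, 2 fluorine; no ring) in place of a group of 6 heavy atoms (4 carbon, 1 oxygen, 1 fluorine; no ring), on a carbonyl carbon. The measured step altered only the group on the oxygen, whereas this change removes the oxygen and its group entirely, so that step bears on it only loosely. Within the data shown here, as that step was modest, no large step in this assay is expected, with the direction uncertain. Compound 3 is therefore estimated at 25 nM, between 8 nM and 80 nM, a step of a 1.3-fold higher number from compound 1 to compound 3 (0.10 log units; within the scatter).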

Compound 3, half-maximal effective concentration: 17.4 nM
The estimate for compound 3 lay 1.4-fold (0.16 log units) above the measured number, and the stated range covers the measured number.
By their numbers in this assay, from the lowest: compounds 2, 3 and 1 (each within the scatter of the next, the first and the last beyond it).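

In this assay, the 1,1-difluoropropyl group, which has no oxygen on the carbonyl carbon, cannot be told apart from the group of compound 1 (a 1.1-fold lower number from compound 1 to compound 3 (0.06 log units; within the scatter)) or from the 1-(trifluoromethyl)ethoxy group of compound 2 (a 1.9-fold higher number from compound 2 to compound 3 (0.28 log units; within the scatter)). At this position, then, the oxygen of compounds 1 and 2 is not required for a number in this range. Nothing available explains this result.

As far as these compounds go, the part played by the two fluorines of compound 3 remains open. So does the effect of a plain propyl group or a dimethylamino group on this carbonyl carbon.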